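Swapping one aryl group in a thiazole–pyrimidinone pair

This account rests on a few compounds, and the source may have more. Where it says the series, first, only, none or still open, it means among the compounds named here.

Measured so far:
- compound 1, `COc1ccc(-c2nc(C)c(C(=O)CSc3nc(-c4cccc(OC)c4)c(C#N)c(=O)[nH]3)s2)cc1`: 12.4%
- compound 2, `Cc1nc(-c2ccc(Cl)cc2)sc1C(=O)CSc1nc(-c2ccc(Cl)cc2)c(C#N)c(=O)[nH]1`: 12.8%

In a functional assay on U-87MG ATCC cells for antiproliferative activity against U-87 MG (Homo sapiens), read by MTT assay, with a stated time of 48 h, tested at 100 uM (a higher number here means a weaker effect of the compound at the concentration tested, a lower number a stronger effect), compound 1 gives 12.4%. In this assay compound 2 gives 12.8%. These two numbers lie within the usual scatter of each other, so neither compound can be set apart from the other on this evidence; compound 2 stands level with compound 1.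

Compound 3, `COc1cccc(-c2nc(SCC(=O)c3sc(-c4ccc(Cl)cc4)nc3C)[nH]c(=O)c2C#N)c1`, has not yet been measured. It differs from compound 2 in one place: 3-methoxyphenyl in place of 4-chlorophenyl on an aromatic carbon. The new group is the same one that compound 1 carries at that position, and compound 1 and compound 2 give matching numbers. Among the compounds with values here, no step between measured compounds is available, so the expectation rests on that match alone.

The step from compound 2 to compound 3 is expected to be a number 0.3 percentage points lower from compound 2 to compound 3 (within the scatter), no change beyond the scatter. Compound 3 is estimated at 12.5%, between 5% and 24%.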

Compound 3, a percentage reported as activity, at one concentration (the size of the read-out at that concentration, not a potency): 8.54%
Estimate against measurement, compound 3: 4 percentage points above; measured number inside the range.
By their numbers in this assay, from the lowest: compounds 3, 1 and 2 (each within the scatter of the next).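

In this assay, 3-methoxyphenyl in place of 4-chlorophenyl, on the aromatic carbon next to the ring nitrogen and ortho to the cyano group, gives a number 4.3 percentage points lower from compound 2 to compound 3 (within the scatter), so this position tolerates either aryl group with no change that can be told from scatter. The second available comparison, chloro in place of methoxy on an aromatic carbon elsewhere in the molecule, gives a number 3.9 percentage points lower from compound 1 to compound 3 (within the scatter), and it too cannot be distinguished from scatter. Nothing measured here offers an explanation for these numbers.

From the compounds shown here alone, whether an aryl group carrying an amine or a carboxylic acid, or a saturated ring such as cyclohexyl, would read differently at this position remains open. Going by these compounds, with a single tested concentration, potency also remains open, since these compounds could differ at lower concentrations.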